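The source may report more compounds than this note shows. Statements on the series, on what has been measured and on what is new or still open speak of the compounds shown alone.

Working notes on the series. In a physicochemical assay for solubility, read by HPLC, using the shake flask method, measured as kinetic solubility, with a stated time of 20 h, at pH 6.5, tested at 200 uM (a higher number here means a more soluble compound, a lower number a less soluble compound), compound 1 `O=S(=O)(c1cccc(Nc2ccc3nccc(-c4ccncc4)c3n2)c1)N1CCCCC1` gives 15000 nM and holds the lower of the two actual numbers in hand. Compound 2 `O=S(=O)(CCO)c1cccc(-c2ccc3nccc(-c4ccncc4)c3n2)c1` gives 55000 nM and stands higher than compound 1 by a gap beyond the scatter. Compound 3 `NS(=O)(=O)c1ccccc1-c1ccc2nccc(-c3ccncc3)c2n1` gives < 5000 nM as its entry in this assay and this is a limit of the assay, not a number.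

Compound 4 `NCCNS(=O)(=O)c1cccc(Nc2ccc3nccc(-c4ccncc4)c3n2)c1` is still unmeasured. It keeps the core of compound 1 and carries (2-aminoethyl)amino in place of piperidin-1-yl on a sulfonyl sulfur. In other words, (piperidin-1-yl)sulfonyl becomes (2-aminoethyl)sulfamoyl. Going by the values given here, no measured pair differs in one place only, so no direct precedent exists for this change.

The expectation is therefore a judgement from the structures. The ring leaves, hydrogen-bond donors enter, and the series is known to reach higher numbers than compound 1, as compound 2 shows with 55000 nM on record. A rise beyond the scatter is expected, an estimated 4.7-fold higher number from compound 1 to compound 4 (0.67 log units; beyond the scatter) in this assay for this change. For compound 4 the expected value is 70000 nM with an estimated range of 25000 nM to 180000 nM until the measurement is in.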

Compound 4, solubility: 200000 nM
For compound 4 the middle estimate is 2.9-fold (0.46 log units) below the measured one, and the stated range ends below it.
By their numbers in this assay, from the lowest: compound 1; then compound 2; then compound 4. At a limit, below all of these: compound 3.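

In this assay, the substituent on the sulfonyl sulfur proves able to move the read-out on its own: (2-aminoethyl)amino in place of piperidin-1-yl gives a 13-fold higher number from compound 1 to compound 4 (1.12 log units; beyond the scatter), a large step. Going by these compounds alone, this is the first pair that differs in one place only, so this change now has a direct measured precedent on the core of compound 1. The values shown include no measured property of either group, so they give no account of why the step is this large.

The change removes a ring and brings in an open chain with hydrogen-bond donors in a single move, so this pair cannot assign the step to either part; a morpholine ring, a dimethylamino group or a 2-hydroxyethylamino chain on the same sulfonyl sulfur would help separate them. Also open, from the compounds shown here alone, is whether a longer aminoalkyl chain or a chain ending in a carboxylic acid would give a step of similar size.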